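A few compounds are considered here, and "the series" means these few. Any claim that something is new, unique, unknown or untested is made for them only; others in the source may bear on it.

Working notes on the series, a functional assay on HepG2 cells (Homo sapiens) for cytotoxicity, read by MTT assay, with a stated time of 72 h (a lower number here means a stronger inhibitor, a higher number a weaker inhibitor), throughout.

Of the compounds shown here, three have numbers so far. Compound 1 `CNC(=O)c1cc(Oc2ccc(NC(=O)c3nn(-c4ccc(Br)cc4F)c(=O)cc3C)cc2F)ccn1` gives 2830 nM. Compound 2 `Cc1cc(=O)n(-c2ccc(Br)cc2F)nc1C(=O)Nc1ccc(Oc2ncnc3ccsc23)cc1` gives 10600 nM. Compound 3 `Cc1cc(=O)n(-c2ccccc2C(F)(F)F)nc1C(=O)Nc1ccc(Oc2ncnc3ccsc23)c(F)c1` gives 9380 nM. Among these, compound 3 holds the second highest number of the three: its number sits within the scatter of that of compound 2, so no order between the two can be read, while compound 1 lies clearly lower, beyond the scatter, and is the only one of the three that separates from compound 3.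

Among the compounds with values here, no pair of measured compounds differs in a single place, so no single-change step is available as a yardstick.

The next compound, compound 4 `Cc1cc(=O)n(-c2ccc(Br)cc2F)nc1C(=O)Nc1ccc(Oc2ncnc3ccsc23)c(F)c1`, is compound 3 with one change: 4-bromo-2-fluorophenyl in place of 2-(trifluoromethyl)phenyl on an aromatic nitrogen. The entering 4-bromo-2-fluorophenyl on an aromatic nitrogen of a six-membered aromatic ring with 2 nitrogen is also the group carried by compound 2, whose number in this assay is 10600 nM, close to that of compound 3. On that basis the step from compound 3 to compound 4 is expected to be small, a 1.1-fold higher number from compound 3 to compound 4 (0.03 log units; within the scatter), with no direction beyond the scatter. Compound 4 is therefore estimated at 10000 nM, with a range from 4000 nM to 25000 nM.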

Compound 4, half-maximal inhibitory concentration: 3350 nM
Compound 4: the middle estimate sits 3.0-fold (0.47 log units) above what was measured; measured number outside the range, below it.
By their numbers in this assay, from the lowest: compounds 1 and 4 (each within the scatter of the next); then compounds 3 and 2 (each within the scatter of the next).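

In this assay, the group on the aromatic nitrogen now has its first single-place reading: with 4-bromo-2-fluorophenyl in place of 2-(trifluoromethyl)phenyl, the series shows a 2.8-fold lower number from compound 3 to compound 4 (0.45 log units; beyond the scatter), so this position responds to this exchange of aryl groups. Compound 4 also gives two further single-place readings: fluoro in place of hydrogen on an aromatic carbon gives a 3.2-fold lower number from compound 2 to compound 4 (0.50 log units; beyond the scatter), a step of similar size that also lies beyond the scatter, whereas the group of 9 heavy atoms in place of the group of 10 heavy atoms, on an oxygen on an aromatic ring, gives a 1.2-fold higher number from compound 1 to compound 4 (0.07 log units; within the scatter), so compounds 1 and 4 cannot be ordered. No measurement at hand accounts for any of these steps.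

The compounds shown leave open which part of the 4-bromo-2-fluorophenyl group carries the step, and a plain phenyl or a 4-chlorophenyl on the aromatic nitrogen would bear on that. They also leave open whether the fluoro step holds with 2-(trifluoromethyl)phenyl on the aromatic nitrogen, and how a chloro or a methoxy group would read on that aromatic carbon.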